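A cyano to chloro exchange at the assay limit

This account rests on a few compounds, and the source may have more. Where it says the series, first, only, none or still open, it means among the compounds named here.

Compounds measured in a functional assay on PANC-1 cells (Homo sapiens) for cytotoxicity, read by WST assay, with a stated time of 24 h; on this read-out higher numbers stand for weaker inhibition and lower numbers for stronger inhibition:
Compound 1 `O=C(/C=C/CCCCCCc1ccccc1)N[C@H]1CC[C@H](O)CC1`: > 100000 nM
Compound 2 `O=C(/C=C/CCCCC#Cc1ccccc1)N1CCCCC1`: > 100000 nM
Compound 3 `N#Cc1ccc(CCCCCCCCC(=O)N2CCCCC2)cc1`: > 100000 nM

Each of these three readings is a limit of the assay and not a number. For compound 3 the reading > 100000 nM is such a limit, so it sets no rank among the three. The record so far comes down to one observation: the limit of > 100000 nM in this assay, at which 3 of the 3 values shown sit.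

Compound 4 `O=C(CCCCCCCCc1ccc(Cl)cc1)N1CCCCC1` departs from compound 3 with chloro in place of cyano on an aromatic carbon. Among the compounds with values here, no measured pair shows what this exchange does. In this assay no step beyond the scatter is expected, and the likeliest outcome is another limit. That expectation rests on all three measured compounds sitting at the same limit, with a measurable number for compound 4 remaining possible but less likely. The expected change is a number no higher from compound 3 to compound 4 (the limit leaves the size open). Compound 4 is estimated at 100000 nM, with an expected range of 30000 nM to 200000 nM.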

Compound 4, half-maximal inhibitory concentration: 65500 nM
For compound 4 the middle estimate is 1.5-fold (0.18 log units) above the measured one; measured number inside the range.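

In this assay, chloro in place of cyano on this aromatic carbon, para to a large group, gives an at least 1.5-fold lower number from compound 3 to compound 4 (0.18 log units; that floor lies within the scatter). Within the data shown here, compound 4, at 65500 nM, is the only one of the four compounds that gives a number and not a limit, which shows that a reading inside the range of the assay can be obtained with this chain and amide. The size of the step remains undefined, and all other values shown stay at one limit: the limit of > 100000 nM in this assay, at which 3 of the 4 values shown sit.

The compounds shown leave open whether a fluoro, a bromo, a methoxy or a carboxylic acid at this position would also give a number. They also leave open whether chloro would have the same effect on the unsaturated chains of the other compounds or with a different amide.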